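The compounds below may be only part of what the source reports. "The series", "measured", "known", "first", "only" and "open" are said of these compounds alone.

In a functional assay on MCF7 cells (Homo sapiens) for antiproliferative activity (on this read-out lower numbers stand for stronger inhibition and higher numbers for weaker inhibition), compound 1 `CCC(CC)Cn1c(Cc2cc(OC)c(OC)c(OC)c2)nc2c(N)ncnc21` gives 158000 nM, the highest of the three numbers at hand. Compound 2 `C#CCCn1c(Cc2cc(OC)c(OC)c(OC)c2)nc2c(N)nc(F)nc21` gives 25100 nM and compound 3 `C#CCCCn1c(Cc2cc(OC)c(OC)c(OC)c2)nc2c(N)nc(F)nc21` gives 11000 nM; both carry a fluorine on the shared core that compound 1 lacks, so neither differs from compound 1 in one place alone. Going by the values given here, the only single-point step measured, a 2.3-fold lower number from compound 2 to compound 3 (0.36 log units; beyond the scatter), alters the chain on the aromatic nitrogen and is modest. Compound 4 `COc1cc(Cc2nc3c(N)ncnc3n2CC(OC)OC)cc(OC)c1OC` differs from compound 1 by dimethoxymethyl in place of pentan-3-yl on a saturated chain carbon bound to an aromatic nitrogen. Among the compounds with values here, no measured step matches this exchange directly, and the one chain step is small, so the expected change a 1.6-fold lower number from compound 1 to compound 4 (0.20 log units; within the scatter) in this assay is modest, with no clear direction. Compound 4 is therefore estimated at 100000 nM, within 30000 nM to 300000 nM.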

Compound 4, half-maximal inhibitory concentration: 72400 nM
Compound 4: the middle estimate sits 1.4-fold (0.14 log units) above what was measured; the range from low to high includes it.
By their numbers in this assay, from the lowest: compound 3; then compound 2; then compound 4; then compound 1.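

The exchange at this place gives a 2.2-fold lower number from compound 1 to compound 4 (0.34 log units; beyond the scatter) in this assay, the first single-point change measured on the core of compound 1. Pentan-3-yl and dimethoxymethyl have the same count of heavy atoms, so this step shows that replacing carbon with oxygen, which brings in hydrogen-bond acceptors, can shift the number beyond the scatter while the group's heavy-atom count stays the same. Nothing measured here explains why the number moved.

On these data alone, whether an amine or a carboxylic acid on this chain would lower the number further remains open. So does whether a single methoxy group would give a similar step to dimethoxymethyl.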